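From 4-chlorobenzyl to 4-methoxybenzyl: compound 2 to compound 3

The source may report more compounds than this note shows. Statements on the series, on what has been measured and on what is new or still open speak of the compounds shown alone.

In a functional assay on A549 cells (Homo sapiens) for cytotoxicity, read by WST assay, with a stated time of 48 h (a higher number here means a weaker inhibitor, a lower number a stronger inhibitor), compound 1 `N#C/C(=C\c1cn(Cc2ccc(Cl)cc2)c2ccc(Br)cc12)C(=O)c1c[nH]c2ccccc12` gives 24900 nM. Compound 2 `N#C/C(=C\c1cn(Cc2ccc(Cl)cc2)c2ccccc12)C(=O)c1c[nH]c2ccccc12` gives no number, only a limit: > 50000 nM. Compound 2 therefore stands at the limit of > 50000 nM in this assay, at which 1 of the 2 values shown sits, and its true value is not known.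

The next change leads to compound 3 `COc1ccc(Cn2cc(/C=C(\C#N)C(=O)c3c[nH]c4ccccc34)c3ccccc32)cc1`, with methoxy in place of chloro on an aromatic carbon, para to a large group, so that 4-chlorobenzyl becomes 4-methoxybenzyl: methoxy in place of chloro on an aromatic carbon.

Within the data shown here, only one measured step is available, hydrogen in place of bromo, and it amounts to an at least 2.0-fold higher number from compound 1 to compound 2 (0.30 log units; that floor lies within the scatter). It makes a different exchange, so it bears on this change only indirectly, as the sole indication of how far the series moves on a single substitution. Since that step gives only a floor within the scatter, no clear shift in either direction is expected in this assay. The expected outcome is a number no higher from compound 2 to compound 3 (the limit leaves the size open), which is no step beyond the scatter. Compound 3 is estimated at 50000 nM, with an expected range of 20000 nM to 100000 nM, and a report of only a limit would be no surprise.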

Compound 3, half-maximal inhibitory concentration: > 50000 nM
Compound 3: only a limit was reported; the forecaster's own chance of this, stated with the estimate: 60%; the middle value sits exactly at the limit.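

Compound 2 and compound 3 both stand only at a limit in this assay, so no step can be read between them: the limit of > 50000 nM in this assay, at which 2 of the 3 values shown sit.

The compounds shown leave open where the true values of compound 2 and compound 3 lie, and whether 4-chlorobenzyl and 4-methoxybenzyl differ at all in this assay.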